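The compounds below may be only part of what the source reports. "The series", "measured", "known", "first", "only" and "open" are said of these compounds alone.

Measured so far in a functional assay on NCI-H460 cells (Homo sapiens) for antiproliferative activity, read by CCK-8 assay, with a stated time of 72 h, tested at 8 uM; a higher number here means a stronger effect of the compound at the concentration tested, a lower number a weaker effect:
compound 1 `CN1CCN(c2nc(Cl)nc3c2ncn3Cc2ccc(C(=O)Nc3ccccc3N)cc2)CC1`, which gives 55.1%;
compound 2 `CC(C)n1cnc2c(Nc3cccc(Cl)c3)nc(NCOCc3ccc(C(=O)Nc4ccccc4N)cc3)nc21`, which gives 43.2%;
compound 3 `COC(CCn1cnc2c(NCc3ccc(C(=O)Nc4ccccc4N)cc3)nc(Cl)nc21)OC`, which gives 51.2%.

Compound 1 stands at the top of these three numbers. Its nearest neighbour is compound 3, whose value lies within the usual scatter of compound 1, so the two cannot be told apart on these data. Compound 2 lies furthest away, and its gap to compound 1 is beyond the scatter, so compound 1 does show a stronger effect than compound 2 at the concentration tested.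

The step now followed leads from compound 1 to compound 4 `Cc1ccc(Nc2nc(Cl)nc3c2ncn3Cc2ccc(C(=O)Nc3ccccc3N)cc2)cc1`, which has not yet been measured in this assay. The change is (4-methylphenyl)amino in place of 4-methylpiperazin-1-yl on an aromatic carbon. Among the measured compounds shown here, no pair of measured compounds differing in only one place is available, so the size of such a step is not known from the data at hand. Compounds 2 and 3 both carry an amino-linked group on the shared core and sit close to compound 1, which suggests that such swaps move the read-out only modestly.

On that basis the step of a number 5.1 percentage points lower from compound 1 to compound 4 (within the scatter) is expected to be small, if anything slightly downward, and not clearly beyond the scatter. Compound 4 is therefore estimated at 50%, within a range from 32% to 68%.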

Compound 4, a percentage reported as inhibition, at one concentration (the size of the read-out at that concentration, not a potency): 82.5%
Compound 4: the middle estimate sits 32.5 percentage points below what was measured; the whole stated range lies below it.
By their numbers in this assay, from the lowest: compounds 2, 3 and 1 (each within the scatter of the next, the first and the last beyond it); then compound 4.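

In this assay, among the compounds shown here, the aromatic carbon of the shared core that carries this group proves sensitive to what stands on it: (4-methylphenyl)amino in place of 4-methylpiperazin-1-yl gives a number 27.4 percentage points higher from compound 1 to compound 4 (beyond the scatter), the first step in this set that can be read in one place. The two groups are close in size, with 8 heavy atoms entering and 7 leaving, yet the swap also exchanges a six-membered non-aromatic ring for a six-membered aromatic ring of carbon only and adds a hydrogen-bond donor, so heavy-atom count alone does not describe the change. Which of these differences matters cannot be told from one step, and no measurement at hand bears on why the number rises.

The compounds shown leave open whether the aromatic ring or the amino hydrogen carries the step, and phenylamino, cyclohexylamino or piperidin-1-yl at this position would help to separate these features and the role of the methyl group. They also leave open the role of the chloro group shared by compound 1 and compound 4, where an amine or a methoxy group would be the next test.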